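The compounds below may be only part of what the source reports. "The series", "measured", "known", "first", "only" and "open" are said of these compounds alone.

Of the compounds shown here, three have been measured in an assay on CHO cells for displacement of a labelled ligand from prostaglandin D2 receptor 2 (Homo sapiens), read by scintillation counting (a higher number here means a weaker inhibitor, a lower number a stronger inhibitor), so far. Compound 1 `O=C(O)COc1ccccc1C#Cc1ccccc1Cl` gives 747 nM. Compound 3 `O=C(O)COc1ccc(Cl)cc1C#Cc1ccncc1` gives 601 nM. Compound 2 `CCCS(=O)(=O)c1cccc(C#Cc2c(Cl)cccc2OCC(=O)O)c1` gives 55 nM, the lowest of the three numbers, and its gap to compound 3, the nearest of the other two, as well as to compound 1 lies beyond the usual scatter of this assay, so compound 2 can be called the strongest inhibitor of this small set. The three measured compounds differ from one another in several places at once. No single change among them can be tied to a shift in the numbers.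

The next compound, compound 4 `CCCS(=O)(=O)c1cccc(C#Cc2c(OCC(=O)O)cccc2-c2ccsc2)c1`, is built from compound 2 by one change: thiophen-3-yl in place of chloro on an aromatic carbon. The chloro group sits on an aromatic carbon ortho to a large group and meta to a carboxymethoxy group, and a thiophen-3-yl group takes its place there.

Among the measured compounds shown here, no measured pair shows this kind of exchange, so the expectation rests on little. The step from compound 2 to compound 4 in this assay is estimated as a small one, a 1.8-fold higher number from compound 2 to compound 4 (0.26 log units; within the scatter), not clearly beyond the scatter in either direction. Compound 4 is therefore expected to give about 100 nM, with a range from 25 nM to 400 nM.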

Compound 4, inhibition constant: 18 nM
Compound 4: the middle estimate sits 5.6-fold (0.74 log units) above what was measured; measured number below the stated range.
By their numbers in this assay, from the lowest: compound 4; then compound 2; then compounds 3 and 1 (each within the scatter of the next).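

In this assay, the aromatic carbon ortho to a large group and meta to a carboxymethoxy group now has its first readable step: thiophen-3-yl in place of chloro gives a 3.1-fold lower number from compound 2 to compound 4 (0.49 log units; beyond the scatter), a modest change but one beyond the usual scatter. This position therefore accepts far more than a single atom, since the entering group has 5 heavy atoms and a five-membered aromatic ring against the 1 heavy atom of chloro, and the inhibitor becomes stronger rather than weaker. No measurement shown here bears on why the number falls.

With only one replacement shown, it stays open whether the sulfur of the thiophene matters, or whether a phenyl ring, a furan ring or a plain propyl chain on this carbon would give a similar number. Going by these compounds, it also stays open whether an amine or a carboxylic acid attached to the thiophene ring would move the number further, and whether the same exchange would give a similar step on a different core.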